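A ring swap on the amide side of compound 1

A few compounds are considered here, and "the series" means these few. Any claim that something is new, unique, unknown or untested is made for them only; others in the source may bear on it.

Of the compounds shown here, three sharing one core have been measured in an assay on membranes from brain (Cavia porcellus) for binding affinity to Sigma non-opioid intracellular receptor 1 (Homo sapiens), read by radioligand binding; a lower number here means a stronger inhibitor, a higher number a weaker inhibitor. Compound 1 `O=C(Cc1cccnc1)NC1CCN(Cc2ccccc2)CC1` gives 269 nM. Compound 2 `O=C(Cc1c[nH]c2ccccc12)NC1CCN(Cc2ccccc2)CC1` gives 10.9 nM, and compound 3 `COc1ccc2[nH]cc(CC(=O)NC3CCN(Cc4ccccc4)CC3)c2c1` gives 125 nM. Among these three, compound 1 has the highest number; compound 3 lies nearest to it, and compound 2 lies furthest away. Among the compounds with values here, the only single-point comparison available is an 11-fold higher number from compound 2 to compound 3 (1.06 log units; beyond the scatter), a methoxy in place of hydrogen on an aromatic carbon.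

Compound 4 `O=C(CSc1ncccn1)NC1CCN(Cc2ccccc2)CC1` has not yet been measured. It differs from compound 1 in one place: (pyrimidin-2-yl)sulfanyl in place of pyridin-3-yl on a saturated chain carbon bound to a carbonyl carbon. Within the data shown here, none of the measured steps concerns this kind of change; the methoxy step from compound 2 to compound 3 alters a different part of the molecule, and compound 1 and compound 2 differ in their whole aromatic group without a counted step between them. The values of compound 1 and compound 2 do show that the group at this position can shift the number considerably, so the replacement in compound 4 could move it either way. Without a guiding precedent, the step of a 1.1-fold lower number from compound 1 to compound 4 (0.03 log units; within the scatter) is expected to be small. For compound 4 the estimate in this assay is 250 nM, within a range from 70 nM to 900 nM.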

Compound 4, inhibition constant: 150 nM
The estimate for compound 4 lay 1.7-fold (0.22 log units) above the measured number; the measured number falls inside the stated range.
By their numbers in this assay, from the lowest: compound 2; then compounds 3, 4 and 1 (each within the scatter of the next, the first and the last beyond it).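

In this assay, putting (pyrimidin-2-yl)sulfanyl in place of pyridin-3-yl on a saturated chain carbon bound to a carbonyl carbon amounts to a 1.8-fold lower number from compound 1 to compound 4 (0.25 log units; within the scatter), so this step cannot be told apart from the ordinary spread of repeated measurements. Within the data shown here, it is the first step read at this position, and it shows that this exchange, which brings in a sulfur atom and a second ring nitrogen and adds one heavy atom, leaves the number within that spread. No measurement shown gives a reason for this outcome.

The exchange alters the ring and the link to the chain in a single step, so the contributions of the sulfur and of the second ring nitrogen cannot be separated here. The parent pairs that would separate them are a compound with (pyridin-3-yl)sulfanyl at this place and one with pyrimidin-2-yl directly on the chain carbon, and the compounds shown also leave open how an amine or a carboxylic acid on the ring would fare.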